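Chloro to 4-chlorophenyl on the shared core

The source may hold more compounds than are shown below. What is called first, only, known or untested is meant among the compounds shown, and "the series" means these compounds.

Values in a functional assay on CCRF-CEM cells (Homo sapiens) (on this read-out lower numbers stand for stronger inhibition and higher numbers for weaker inhibition), so far:
Compound 1 `Cc1ccc(-c2ncnc3c2ncn3C[C@@H]2C[C@H](CO)c3ccccc32)cc1` gives 1.4 ug/mL
Compound 2 `OC[C@H]1C[C@@H](Cn2cnc3c(Cl)ncnc32)c2ccccc21` gives 24 ug/mL
Compound 3 `Cn1ncc2c1[C@H](Cn1cnc3c(Cl)nc(N)nc31)C[C@@H]2CO` gives 3.2 ug/mL

Compound 2 has the highest number of the three, which makes it the weakest inhibitor here. Compound 4 `OC[C@H]1C[C@@H](Cn2cnc3c(-c4ccc(Cl)cc4)ncnc32)c2ccccc21` puts 4-chlorophenyl in place of its chloro on an aromatic carbon (4-chlorophenyl in place of chloro on an aromatic carbon). Among the compounds with values here, one measured step bears on this (a 17-fold higher number from compound 1 to compound 2 (1.23 log units; beyond the scatter)), where chloro replaced 4-methylphenyl. Read in reverse, that large step suggests an aryl group lowers the number, although 4-chlorophenyl has not itself been measured on this core. Compound 3 differs in more than one place and offers no direct guide. In this assay a large step to a lower number is expected (a 9.6-fold lower number from compound 2 to compound 4 (0.98 log units; beyond the scatter)), perhaps somewhat smaller than the measured one. Compound 4 is expected at 2.5 ug/mL (estimated range 0.8 ug/mL to 8 ug/mL).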

Compound 4, half-maximal inhibitory concentration: 0.63 ug/mL
The estimate for compound 4 lay 4.0-fold (0.60 log units) above the measured number; measured number outside the range, below it.
By their numbers in this assay, from the lowest: compound 4; then compound 1; then compound 3; then compound 2.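

In this assay, putting 4-chlorophenyl in place of chloro on this aromatic carbon gives a 38-fold lower number from compound 2 to compound 4 (1.58 log units; beyond the scatter), so the drop seen with the 4-methylphenyl group of compound 1 also holds for a second substituted phenyl ring. The substituent on that ring has a smaller effect: chloro in place of methyl gives a 2.2-fold lower number from compound 1 to compound 4 (0.35 log units; beyond the scatter). No measurement here explains either step. On these data alone, it remains open how an unsubstituted phenyl ring would compare, and whether an amine on this carbon would also lower the number.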